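A furan-2-yl in place of the 4-fluorophenyl

The source may hold more compounds than are shown below. What is called first, only, known or untested is meant among the compounds shown, and "the series" means these compounds.

Compound 1 `COc1ccc(-c2nc3cccc(-c4cc(OC)c(OC)c(OC)c4)c3o2)cc1` gives > 25000 nM in a functional assay on U-251 cells (Homo sapiens) for antiproliferative activity, read by MTT assay, with a stated time of 48 h (a higher number here means a weaker inhibitor, a lower number a stronger inhibitor), which is a limit of the assay. Compound 2 `COc1cc(-c2cccc3nc(-c4ccc(F)cc4)oc23)cc(OC)c1OC` gives > 25000 nM in this assay, again a limit. Compound 3 `COc1cc(-c2cccc3nc(-c4cccc(N)c4)oc23)cc(OC)c1OC` gives 2200 nM in this assay.

Compound 2 therefore stands at the limit of this assay, where two of the three values sit (the limit of > 25000 nM in this assay, at which 2 of the 3 values shown sit), and no number is known for it. Compound 4 `COc1cc(-c2cccc3nc(-c4ccco4)oc23)cc(OC)c1OC` differs from compound 2 by furan-2-yl in place of 4-fluorophenyl on an aromatic carbon. For the measured compounds named here, no measured step involves a furan-2-yl. The steps that come closest are an at least 11-fold lower number from compound 2 to compound 3 (1.05 log units; beyond the scatter) and an at least 11-fold lower number from compound 1 to compound 3 (1.05 log units; beyond the scatter), both large, both leading to the 3-aminophenyl; the step that the two limits leave unreadable from compound 1 to compound 2 stays between two limits. The furan-2-yl is not the 3-aminophenyl, so the large drop seen with compound 3 is not expected to carry over, and compound 4 is expected to remain weak, with an at least 1.2-fold lower number from compound 2 to compound 4 (0.09 log units; that floor lies within the scatter) as the likely step. The estimate for compound 4 is 20000 nM, in the range 4000 nM to 60000 nM, with a good chance that only a limit is reported.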

Compound 4, half-maximal inhibitory concentration: 10600 nM
Estimate against measurement, compound 4: 1.9-fold (0.28 log units) above; measured number inside the range.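

In this assay the position next to the ring nitrogen and next to the ring oxygen gives a measurable number with a group other than the 3-aminophenyl, since the furan-2-yl brings an at least 2.3-fold lower number from compound 2 to compound 4 (0.37 log units; beyond the scatter) and an at least 2.3-fold lower number from compound 1 to compound 4 (0.37 log units; beyond the scatter) and so a readable value here does not rest on the 3-aminophenyl alone. For the compounds shown here, the furan-2-yl still falls short of the 3-aminophenyl, with a 4.8-fold higher number from compound 3 to compound 4 (0.68 log units; beyond the scatter) as the step, which gives these two groups an order that the earlier compounds could not show. The steps from compound 1 and compound 2 give only a floor, and their true size stays unknown: the limit of > 25000 nM in this assay, at which 2 of the 4 values shown sit.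

The compounds shown leave open whether another five-membered aromatic ring such as thiophen-2-yl would behave like the furan-2-yl. They also leave open how a 4-aminophenyl or a 3-hydroxyphenyl would compare with the 3-aminophenyl.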